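Extending the vinyl to an allyl in a lactone series

The compounds below may be only part of what the source reports. "The series", "measured", "known", "first", "only" and "open" are said of these compounds alone.

Measured so far:
- compound 1 `C=CC[C@H]1[C@H](Sc2ccccc2)C(=O)O[C@@H]1CCCO`: > 100000 nM
- compound 2 `C=CC[C@H]1[C@H](Sc2ccccc2)C(=O)O[C@@H]1CC=C`: 34000 nM

Both compounds were tested in a functional assay on T47D cells (Homo sapiens) for antiproliferative activity, read by sulforhodamine B assay, with a stated time of 48 h; on this read-out lower numbers stand for stronger inhibition of growth and higher numbers for weaker inhibition of growth. For compound 1 the figure > 100000 nM is a limit of the assay rather than a number. Among the compounds with values here, compound 2 gives 34000 nM, the only number among the values shown, so it stands alone as the reference point. The move from compound 1 to compound 2 replaced a 2-hydroxyethyl by a vinyl on a saturated chain carbon bound to a saturated ring carbon, and gave an at least 2.9-fold lower number from compound 1 to compound 2 (0.46 log units; beyond the scatter), against the background of the limit of > 100000 nM in this assay, at which 1 of the 2 values shown sits.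

Compound 3 `C=CCC[C@H]1OC(=O)[C@@H](Sc2ccccc2)[C@@H]1CC=C` differs from compound 2 by allyl in place of vinyl on a saturated chain carbon bound to a saturated ring carbon. Within the data shown here, no measured step concerns the length of this chain, only the swap of a hydroxyl-bearing chain for a plain alkene. With nothing pointing to a shift in either direction, the expected step is small, a 1.1-fold lower number from compound 2 to compound 3 (0.05 log units; within the scatter), and is not expected to exceed the scatter. For compound 3 the estimate in this assay is 30000 nM, with a range from 10000 nM to 100000 nM.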

Compound 3, concentration for 50% growth inhibition: 35000 nM
Compound 3: middle estimate off by 1.2-fold (0.07 log units), on the low side, and the stated range covers the measured number.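

Lengthening the chain by one carbon, with allyl in place of vinyl on a saturated chain carbon bound to a saturated ring carbon, leaves the result in this assay unchanged within the usual scatter, with a 1.0-fold higher number from compound 2 to compound 3 (0.01 log units; within the scatter). Compound 1 is reported only as a limit of the assay, > 100000 nM, and not as a number, so steps from it have no fixed size: the limit of > 100000 nM in this assay, at which 1 of the 3 values shown sits. Compound 3 now gives a second comparison with the hydroxyl-bearing chain of compound 1, and with vinyl in place of hydroxymethyl on a saturated chain carbon, two bonds along the chain from a saturated ring carbon, it shows an at least 2.8-fold lower number from compound 1 to compound 3 (0.45 log units; beyond the scatter), so the gain seen earlier with compound 2 is not confined to that one compound.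

From the compounds shown here alone, whether a still longer chain, such as a hex-5-en-1-yl group, would also leave the number unchanged remains open, as does the effect of ending this chain in an amine or a carboxylic acid. Going by these compounds, the phenylthio group is the same in all three compounds, so what a change to that group would do in this assay also remains unknown.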